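The source may report more compounds than this note shows. Statements on the series, on what has been measured and on what is new or still open speak of the compounds shown alone.

Compound 1 `CCOC(=O)c1cnn(-c2nc(-c3ccc(OC)cc3)c(C#N)c(=O)n2C)c1N`: 74 ug/mL
Compound 2 `COc1cccc(-c2nc(NN)n(C)c(=O)c2C#N)c1OC`: 36 ug/mL

In a functional assay, with a stated time of 10 min (on this read-out higher numbers stand for weaker inhibition and lower numbers for stronger inhibition), compound 1 gives 74 ug/mL, the higher of the two numbers and so the weaker inhibition, with a gap to compound 2 just beyond the usual scatter. Compound 3 `CCOC(=O)c1cnn(-c2nc(-c3ccco3)c(C#N)c(=O)n2C)c1N` keeps the core of compound 1 but carries furan-2-yl in place of 4-methoxyphenyl on an aromatic carbon. Within the data shown here, no measured pair tests this exchange, so no step beyond the scatter is expected in this assay, and no firm direction. The expected change is a 1.2-fold lower number from compound 1 to compound 3 (0.09 log units; within the scatter). For compound 3 the estimated value is 60 ug/mL, with an expected range of 25 ug/mL to 150 ug/mL.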

Compound 3, half-maximal inhibitory concentration: 104 ug/mL
Compound 3: the middle estimate sits 1.7-fold (0.24 log units) below what was measured; measured number inside the range.
By their numbers in this assay, from the lowest: compound 2; then compounds 1 and 3 (each within the scatter of the next).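

In this assay the exchange of 4-methoxyphenyl for furan-2-yl on this aromatic carbon gives a 1.4-fold higher number from compound 1 to compound 3 (0.15 log units; within the scatter) and so offers the first direct test of this position: with the rest of compound 1 kept, a five-membered aromatic ring of 5 heavy atoms and a six-membered one of 8 cannot be told apart here. No measurement at hand offers an explanation for this result.

From the compounds shown here alone, whether a plain amine or a carboxylic acid on this carbon would move the number beyond the scatter remains open, as does whether an aromatic ring is needed here at all.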